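The source may report more compounds than this note shows. Statements on the series, on what has been measured and on what is new or still open speak of the compounds shown alone.

Measured compounds in an assay on isolated protein for inhibition of Rho-associated protein kinase 2 (Homo sapiens), read by radiometric assay; a higher number here means a weaker inhibitor, a lower number a stronger inhibitor:
compound 1 `COC(=O)c1cccc(-c2cc(C(=O)Nc3ccncc3F)ccc2CN)c1`; compound 1 gives 7.8 nM
compound 2 `CCCCCCOC(=O)c1cccc(-c2cc(C(=O)Nc3ccncc3)ccc2CN)c1`; compound 2 gives 22 nM
compound 3 `CC(C)OCCOC(=O)c1cccc(-c2cc(C(=O)Nc3ccncc3F)ccc2CN)c1`; compound 3 gives 37 nM

Compound 2 stands second highest of the three numbers in this assay. Its nearest is compound 3, within the scatter; its furthest is compound 1, a lower number beyond the scatter.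

Compound 4 `NCc1ccc(C(=O)Nc2ccncc2)cc1-c1cccc(C(=O)OCC2CCCC2)c1` is not yet measured. It differs from compound 2 by cyclopentyl in place of pentyl on a saturated chain carbon bound to an oxygen next to a carbonyl group. Within the data shown here, the only measured step at the same place is a 4.7-fold higher number from compound 1 to compound 3 (0.68 log units; beyond the scatter), a modest change, and it goes with a different entering group. Compound 2 and compound 3 carry different groups at that place, and their values lie within the scatter of each other. The leaving and entering groups of this change are alike in what is counted, apart from the ring. A step beyond the scatter in this assay is therefore not expected, in either direction. The estimate for compound 4 in this assay is 25 nM, with a range from 10 nM to 65 nM, which means an expected step of a 1.1-fold higher number from compound 2 to compound 4 (0.06 log units; within the scatter).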

Compound 4, half-maximal inhibitory concentration: 5 nM
The estimate for compound 4 lay 5.0-fold (0.70 log units) above the measured number; measured number outside the range, below it.
By their numbers in this assay, from the lowest: compounds 4 and 1 (each within the scatter of the next); then compounds 2 and 3 (each within the scatter of the next).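

In this assay, replacing pentyl with cyclopentyl on the saturated chain carbon bound to an oxygen next to a carbonyl group gives a 4.4-fold lower number from compound 2 to compound 4 (0.64 log units; beyond the scatter). The heavy-atom count and the hydrogen-bond donor and acceptor counts are unchanged, so the ring is the only counted difference accompanying a step beyond the scatter, and the earlier step at this place, a 4.7-fold higher number from compound 1 to compound 3 (0.68 log units; beyond the scatter), had shown only a move to a higher number. No measured evidence bearing on the origin of this step is available.

On these data alone, whether the result depends on ring size remains open, as a cyclobutyl or cyclohexyl group at this place would show. As far as these compounds go, it is also open whether the same change would give a similar step on the core of compound 1, since it is seen here in one pair only.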